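The source may report more compounds than this note shows. Statements on the series, on what has been measured and on what is new or still open speak of the compounds shown alone.

For the measured compounds named here, compound 2 `CC(C)CNC(=O)NCCCOc1cccc(CN2CCCCC2)c1` is one of two compounds so far measured in an assay on isolated protein for inhibition of histamine H2 receptor (Cavia porcellus); a lower number here means tighter binding, a higher number weaker binding. In this assay, going by the values given here, compound 2 gives 170 nM, the higher of the two numbers, although this lies within the scatter of its only neighbour. That neighbour, compound 1 `O=C(NCCCOc1cccc(CN2CCCCC2)c1)Nc1ccccc1`, in this assay gives 126 nM, and the step of a 1.3-fold higher number from compound 1 to compound 2 (0.13 log units; within the scatter) means the two values cannot be ordered with confidence. Compound 3 `CCC(C)NC(=O)NCCCOc1cccc(CN2CCCCC2)c1` has not yet been measured. It differs from compound 2 in one place: sec-butyl in place of isobutyl on an amide-type nitrogen. The isobutyl group leaves and a sec-butyl group of the same atom count enters at the amide-type nitrogen. Among the compounds with values here, the only measured step bears on this position indirectly, since it involved phenyl being replaced by isobutyl there, and that step stayed within the scatter. Within the data shown here, no measured step addresses an exchange of one butyl group for another, so the expectation rests on that single nearby step alone. Compound 3 is expected to give an estimated 200 nM, with a range from 80 nM to 500 nM. This corresponds to an expected step of a 1.2-fold higher number from compound 2 to compound 3 (0.07 log units; within the scatter), not beyond the scatter.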

Compound 3, dissociation constant: 95.5 nM
Compound 3: middle estimate off by 2.1-fold (0.32 log units), on the high side; the measured number falls inside the stated range.
By their numbers in this assay, from the lowest: compounds 3, 1 and 2 (each within the scatter of the next).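

In this assay, the exchange of isobutyl for sec-butyl on the amide-type nitrogen, two groups made of the same atoms joined differently, gives a 1.8-fold lower number from compound 2 to compound 3 (0.25 log units; within the scatter), so the one exchange of a butyl group for another shown here stays inside the scatter, something the earlier step between phenyl and isobutyl could not show. Read with a 1.3-fold lower number from compound 1 to compound 3 (0.12 log units; within the scatter), for sec-butyl in place of phenyl, and with a 1.3-fold higher number from compound 1 to compound 2 (0.13 log units; within the scatter), it shows that all three pairs among phenyl, isobutyl and sec-butyl at this position lie within the scatter, so none of these three groups separates from the others in this assay. Nothing at hand explains how these groups act at this position.

As far as these compounds go, it remains open whether a group of a different kind on this nitrogen, such as a longer chain, an amine or a carboxylic acid, would give a step beyond the scatter. For the compounds shown here, it is also open whether an exchange of isobutyl for sec-butyl would give a similar step on a core other than the one shared by these compounds.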